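Methyl branching on the chain carbon of compound 1

A few compounds are considered here, and "the series" means these few. Any claim that something is new, unique, unknown or untested is made for them only; others in the source may bear on it.

Measured compounds:
Compound 1 `CCCC(C#CC(=O)OC)O/C=C/C(=O)OC` — 320 nM
Compound 2 `CC1CCC(C(C)C)C(OC(=O)C#CC(O/C=C/C(=O)OC2CC(C)CCC2C(C)C)C(C)C)C1` — a limit only: > 100000 nM
Compound 3 `CCCCCCCCCCC(C#CC(=O)OC)O/C=C/C(=O)OC` — 2000 nM

In a functional assay on SW1573 cells (Homo sapiens) for antiproliferative activity, read by sulforhodamine B assay, with a stated time of 48 h (a higher number here means a weaker inhibitor of growth, a lower number a stronger inhibitor of growth), compound 1 gives 320 nM, the lowest of the two numbers shown. Compound 3 gives 2000 nM in this assay. For compound 2 this assay reports only a limit, > 100000 nM; this is the limit of > 100000 nM in this assay, at which 1 of the 3 values shown sits.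

The next compound is compound 4 `CCC(C)C(C#CC(=O)OC)O/C=C/C(=O)OC`, which differs from compound 1 in one place: methyl in place of hydrogen on a saturated chain carbon bound to two saturated chain carbons. Seen one bond further out, the change reads propyl to sec-butyl.

For the measured compounds named here, only one measured step bears on this: a 6.3-fold higher number from compound 1 to compound 3 (0.80 log units; beyond the scatter). That step adds a heptyl on the same chain; the present change adds a single methyl, a far smaller addition, and so only a small part of that step, if any, is expected here.

For compound 4 the expected step is a 1.4-fold higher number from compound 1 to compound 4 (0.15 log units; within the scatter), most likely not beyond the scatter. Compound 4 is estimated at 450 nM, with a range from 200 nM to 1200 nM.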

Compound 4, concentration for 50% growth inhibition: 910 nM
The estimate for compound 4 lay 2.0-fold (0.31 log units) below the measured number; measured number inside the range.
By their numbers in this assay, from the lowest: compound 1; then compound 4; then compound 3. At a limit, above all of these: compound 2.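

In this assay, a single methyl in place of hydrogen on a saturated chain carbon bound to two saturated chain carbons is already enough to move the number: a 2.8-fold higher number from compound 1 to compound 4 (0.45 log units; beyond the scatter). For the compounds shown here, until now the only one-place change on this chain was the much larger heptyl addition, a 6.3-fold higher number from compound 1 to compound 3 (0.80 log units; beyond the scatter), so propyl to sec-butyl shows that even a minimal branch is not silent at this position, and both one-place additions to compound 1 raise the number. Nothing measured here accounts for the step.

On these data alone, whether any replacement at this chain carbon gives a lower number than compound 1 stays open, for example a hydroxyl, an amine or a phenyl. Also open, as far as these compounds go, is how a branch of another size, such as a tert-butyl, compares with sec-butyl.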